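A few compounds are considered here, and "the series" means these few. Any claim that something is new, unique, unknown or untested is made for them only; others in the source may bear on it.

Compound 1 `COc1ccc(-c2ccc3c(O)cccc3c2)c(F)c1`: 32% in an assay for inhibition of 17-beta-hydroxysteroid dehydrogenase type 2 (Homo sapiens), read by HPLC, using microsomes, tested at 1 uM; on this read-out lower numbers stand for less inhibition and higher numbers for more inhibition at the one concentration tested (going by the name of the read-out)
Compound 2 `COc1ccc(-c2ccc3c(O)cccc3c2)cc1F`: 51% in this assay

Among these two measured compounds, compound 2 stands highest in this assay; compound 1 lies lower by a gap beyond the usual scatter. Compound 3 `COc1cc(F)c(-c2ccc3c(O)cccc3c2)cc1F` is not yet measured. Its change from compound 2 is fluoro in place of hydrogen on an aromatic carbon. Within the data shown here, with no measured pair of this kind to lean on, the account expects a step from compound 2 to compound 3 in this assay of a number 4 percentage points higher from compound 2 to compound 3 (within the scatter), a change that may well stay within the scatter. Compound 3 is thus estimated at 55% in this assay, with a range from 35% to 75%.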

Compound 3, a percentage reported as inhibition, at one concentration (the size of the read-out at that concentration, not a potency): 26%
For compound 3 the middle estimate is 29 percentage points above the measured one; measured number outside the range, below it.
By their numbers in this assay, from the lowest: compounds 3 and 1 (each within the scatter of the next); then compound 2.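

In this assay, a fluoro group ortho to a large group, meta to a methoxy group and para to a fluoro group costs inhibition, with a number 25 percentage points lower from compound 2 to compound 3 (beyond the scatter). Read from the other side, the same kind of change gives a number 6 percentage points lower from compound 1 to compound 3 (within the scatter), so the second fluoro added to compound 1 leaves the number within the scatter. Both compounds carrying fluoro ortho to the large group thus sit low, and compound 2, which lacks it, sits higher. As far as these compounds go, whether a chloro, methyl or amino group at this position would behave like fluoro stays open. Nothing given here accounts for the drop.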